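A few compounds are considered here, and "the series" means these few. Any claim that something is new, unique, unknown or untested is made for them only; others in the source may bear on it.

Compound 1 `C=CCONC(=O)CN1C(=O)S/C(=C\c2ccccc2)C1=O`: > 128000 nM
Compound 2 `C=CCONC(=O)CN1C(=O)S/C(=C\c2ccc(F)cc2)C1=O`: > 128000 nM
Compound 3 `CCCC/C=C1\SC(=O)N(CC(=O)NOCc2ccccc2)C1=O`: > 128000 nM

Each of these entries is a limit of the assay and not a number. In an ADME assay on RAW264.7 cells (Mus musculus) for cytotoxicity, read by neutral red uptake, with a stated time of 24 h (on this read-out higher numbers stand for lower toxicity in this test and lower numbers for higher toxicity in this test), compound 3 gives > 128000 nM, which is a limit. Compound 3 thus stands at the limit of > 128000 nM in this assay, at which 3 of the 3 values shown sit.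

Compound 4 `C=CCONC(=O)CN1C(=O)S/C(=C\CCCC)C1=O` differs from compound 3 in one place: vinyl in place of phenyl on a saturated chain carbon bound to an oxygen. This puts vinyl in place of phenyl on a saturated chain carbon bound to an oxygen, so benzyloxy becomes allyloxy. Among the measured compounds shown here, the only measured step, a step that the two limits leave unreadable from compound 1 to compound 2, is a different change and offers no size to carry over. Allyloxy already occurs in compound 1, whose entry is also a limit: > 128000 nM. No step beyond the scatter is therefore expected in this assay, and the expected change is a number no higher from compound 3 to compound 4 (the limit leaves the size open). Compound 4 is estimated at 128000 nM, with an expected range of 70000 nM to 256000 nM.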

Compound 4, half-maximal cytotoxic concentration: > 128000 nM
Compound 4: no number, only a limit (the forecaster's own chance of this, stated with the estimate: 85%); the middle value sits exactly at the limit.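

No step can be read from compound 1, compound 2 or compound 3 to compound 4, since every entry is a limit of the assay: the limit of > 128000 nM in this assay, at which 4 of the 4 values shown sit. The compounds shown leave open where each true value lies in this assay, and whether any of these changes shifts it.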